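A few compounds are considered here, and "the series" means these few. Any claim that something is new, unique, unknown or untested is made for them only; others in the source may bear on it.

Measured so far in an ADME assay on Huh-7 cells (Homo sapiens) for cytotoxicity, with a stated time of 72 h; a lower number here means that less compound is tolerated, a higher number that more compound is tolerated:
compound 1, `CC(C)CCn1nc(-c2ccccc2)c(O)c(C2=NS(=O)(=O)c3cc(NS(C)(=O)=O)ccc3N2)c1=O`, gives > 1000 nM
compound 2, `COCCn1nc(-c2cccs2)c(O)c(C2=NS(=O)(=O)c3cc(NS(C)(=O)=O)ccc3N2)c1=O`, gives > 1000 nM

Both entries are limits of the assay rather than numbers. For compound 2 the result in this assay is the limit > 1000 nM, so no figure is known for where it sits; the same is true of compound 1, whose value in this assay is the limit > 1000 nM. Going by the values given here, the series so far therefore rests on (the limit of > 1000 nM in this assay, at which 2 of the 2 values shown sit), and nothing measured separates the two compounds.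

Compound 3 is `CS(=O)(=O)Nc1ccc2c(c1)S(=O)(=O)N=C(c1c(O)c(-c3cccs3)nn(CCC3CCCCC3)c1=O)N2` and remains to be tested in this assay. It differs from compound 2 by cyclohexyl in place of methoxy on a saturated chain carbon, two bonds along the chain from an aromatic nitrogen.

Among the compounds with values here, no step between measured compounds is available, and no change elsewhere in this set has moved a value off the limit. The expectation is that the step from compound 2 to compound 3 stays within the scatter, with no direction to it, and that compound 3 is again reported only as a limit; the expected step is a step that the limit leaves unreadable from compound 2 to compound 3. Compound 3 is estimated at 3000 nM in this assay, with a range from 1000 nM to 10000 nM.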

Compound 3, half-maximal cytotoxic concentration: > 17000 nM
Compound 3: no number, only a limit; the forecaster's own chance of this, stated with the estimate: 85%; middle value at least 5.6-fold (0.75 log units) away from the limit.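

In this assay compound 3 gives > 17000 nM as a limit and not a number. Compound 2 gives > 1000 nM as a limit too, so no step can be read between compound 2 and compound 3. What the compounds shown leave open is the concentration in this assay at which any of them becomes cytotoxic, and whether cyclohexyl in place of methoxy shifts it.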